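The source may report more compounds than this note shows. Statements on the series, on what has been measured and on what is new or still open speak of the compounds shown alone.

Compound 3 `COc1cc(Cn2cc(CNC(=O)c3cn(-c4ccccc4)nc3-c3ccc(F)cc3)nn2)cc(OC)c1OC` gives 4300 nM in a functional assay on MCF7 cells (Homo sapiens) for antiproliferative activity, read by sulforhodamine B assay, with a stated time of 48 h (a lower number here means a stronger inhibitor of growth, a higher number a weaker inhibitor of growth), the highest of the three numbers seen so far: compound 2 `COc1cc(Cn2cc(CNC(=O)c3cn(-c4ccccc4)nc3-c3ccc(F)cc3)nn2)cc(OC)c1` gives 2500 nM, within the scatter of it, and compound 1 `O=C(NCc1cn(Cc2ccc(C(F)(F)F)cc2)nn1)c1cn(-c2ccccc2)nc1-c1ccc(F)cc1` gives 810 nM. The steps measured to date, a 3.1-fold higher number from compound 1 to compound 2 (0.49 log units; beyond the scatter), a 5.3-fold higher number from compound 1 to compound 3 (0.72 log units; beyond the scatter) and a 1.7-fold higher number from compound 2 to compound 3 (0.24 log units; within the scatter), all concern the group on the saturated chain carbon bound to an aromatic nitrogen. Compound 4 `COc1ccc(-c2nn(-c3ccccc3)cc2C(=O)NCc2cn(Cc3cc(OC)c(OC)c(OC)c3)nn2)cc1` differs from compound 3 elsewhere: methoxy in place of fluoro on an aromatic carbon. Among the measured compounds shown here, no measured step touches that ring, so the series offers no direction for this change. The expectation for compound 4 is therefore a step of a 1.0-fold higher number from compound 3 to compound 4 (0.02 log units; within the scatter), within the scatter. Compound 4 is estimated at 4500 nM in this assay, with a range from 1800 nM to 11000 nM.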

Compound 4, concentration for 50% growth inhibition: 7600 nM
For compound 4 the middle estimate is 1.7-fold (0.23 log units) below the measured one; the measured number falls inside the stated range.
By their numbers in this assay, from the lowest: compound 1; then compounds 2, 3 and 4 (each within the scatter of the next, the first and the last beyond it).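

In this assay, among the compounds shown here, the first change on this ring, 4-fluorophenyl to 4-methoxyphenyl, gives a 1.8-fold higher number from compound 3 to compound 4 (0.25 log units; within the scatter), so the two groups cannot be told apart here with the 3,4,5-trimethoxyphenyl group held constant. For the compounds shown here, the result covers only this one pair, and the added oxygen brings no difference that can be read. Nothing available explains the result.

Going by these compounds, whether the same holds alongside the 4-(trifluoromethyl)phenyl group of compound 1 remains open. So does the effect of an amine or a carboxylic acid at this ring position.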